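This account rests on a few compounds, and the source may have more. Where it says the series, first, only, none or still open, it means among the compounds named here.

Measured in a functional assay on HEK293 cells (Homo sapiens) for inhibition; a lower number here means a stronger inhibitor, a higher number a weaker inhibitor:
Compound 1, `CCCCCCCCCCS(=O)(=O)NCCCN(CCCNCCCCNCCCN)CCCNS(=O)(=O)CCCCCCCCCC`, gives 5170 nM.
Compound 2, `CCCCCCCCCCCCS(=O)(=O)NCCCN(CCCNCCCCNCCCN)CCCNS(=O)(=O)CCCCCCCCCCCC`, gives 13200 nM.
Compound 3, `CCCCCCCCCCS(=O)(=O)NCCCN(CCCNCCCNCCCCNCCCN)CCCNS(=O)(=O)CCCCCCCCCC`, gives 2200 nM.

Compound 3 differs from compound 1 by (4-((3-aminopropyl)amino)butyl)amino in place of ((3-aminopropyl)amino)methyl on a saturated chain carbon, three bonds along the chain from an amine nitrogen, and that change made a 2.4-fold lower number from compound 1 to compound 3 (0.37 log units; beyond the scatter). Compound 2 stands highest of the three numbers; how its core differs from the core of compound 1 is not broken down here, and the two values alone show compound 2 with the weaker inhibition. Compound 4, `CCCCCCCCCCCCS(=O)(=O)NCCCN(CCCNCCCNCCCCNCCCN)CCCNS(=O)(=O)CCCCCCCCCCCC`, is not yet measured; it differs from compound 2 by (4-((3-aminopropyl)amino)butyl)amino in place of ((3-aminopropyl)amino)methyl on a saturated chain carbon, three bonds along the chain from an amine nitrogen, the same change at the same place as before. For compound 4 a step of about the same size is expected, a 2.4-fold lower number from compound 2 to compound 4 (0.38 log units; beyond the scatter), because the earlier step read a 2.4-fold lower number from compound 1 to compound 3 (0.37 log units; beyond the scatter). Compound 4 is therefore estimated at 5500 nM, with a likely range from 2500 nM to 12000 nM.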

Compound 4, half-maximal inhibitory concentration: 16400 nM
Estimate against measurement, compound 4: 3.0-fold (0.47 log units) below; measured number above the stated range.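

Putting (4-((3-aminopropyl)amino)butyl)amino in place of ((3-aminopropyl)amino)methyl in this assay gave a 1.2-fold higher number from compound 2 to compound 4 (0.09 log units; within the scatter), so on this core the change made no difference that can be read. The lower number seen on the core of compound 1 did not carry over to the core of compound 2: the same change on two cores in this assay, a 2.4-fold lower number (0.37 log units; beyond the scatter) from compound 1 to compound 3 and a 1.2-fold higher number (0.09 log units; within the scatter) from compound 2 to compound 4, 2.9-fold (0.47 log units) apart, beyond the scatter of two such steps This single pair of cores shows that the size of the step depended on the core here, but it does not show why, or what the change would do on any other core.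

As far as these compounds go, whether an octyl chain on the sulfonamide would behave like the core of compound 1 remains open. So does whether a guanidine in place of the terminal amine would follow either core.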